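This account rests on a few compounds, and the source may have more. Where it says the series, first, only, none or still open, it means among the compounds named here.

Measured in a functional assay on B16 cells (Mus musculus) for inhibition, with a stated time of 72 h; on this read-out higher numbers stand for weaker inhibition and lower numbers for stronger inhibition:
- compound 1 `Cc1ccc(CN2CCNC2=S)cc1`: 4800 nM
- compound 2 `S=C1NCCCN1Cc1ccccc1`: > 10000 nM

Compound 2 has no exact number on this read-out. Its result, > 10000 nM, is a limit of this assay.

Compound 3 `CCc1ccc(CN2CCCNC2=S)cc1` differs from compound 2 in one place: ethyl in place of hydrogen on an aromatic carbon. In words, this is ethyl in place of hydrogen on an aromatic carbon. Among the measured compounds shown here, no measured pair shows the effect of this change alone, so any forecast rests on thin ground. For the measured compounds named here, the only exact number available in this assay belongs to compound 1, at 4800 nM, and the expectation leans on that value. Somewhat stronger inhibition is expected, with a modest estimated step of an at least 1.6-fold lower number from compound 2 to compound 3 (0.22 log units; that floor lies within the scatter). For compound 3 the estimated value is 6000 nM, with an expected range of 2000 nM to 15000 nM.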

Compound 3, half-maximal inhibitory concentration: 1300 nM
Estimate against measurement, compound 3: 4.6-fold (0.66 log units) above; measured number below the stated range.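

In this assay, ethyl in place of hydrogen on an aromatic carbon, para to a group of 8 heavy atoms, gives an at least 7.6-fold lower number from compound 2 to compound 3 (0.88 log units; beyond the scatter). Among the compounds shown here, this is the first pair in which this one change can be read alone, and it shows that a group placed here on the six-membered aromatic ring goes with clearly stronger inhibition on this core. Compound 2 stands only as a limit, so the step is a floor and its full size stays unknown: the limit of > 10000 nM in this assay, at which 1 of the 3 values shown sits.

At this place on this core, the compounds shown compare only hydrogen and ethyl, so it stays open whether ethyl itself matters or whether other groups would serve as well. A methyl group, a longer chain such as butyl, a methoxy group or an amine at the same place could each go either way.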